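This account rests on a few compounds, and the source may have more. Where it says the series, first, only, none or still open, it means among the compounds named here.

Three compounds share one core and differ only in the group on a saturated ring carbon. Compound 1 `CCC1C(=O)N(C)c2cnc(Nc3ccc(S(N)(=O)=O)cc3)nc2N1C` gives 479 nM in an assay on Sf9 cells for inhibition of serine/threonine-protein kinase 4 (Homo sapiens), read by luminescence and ADP-Glo, with a stated time of 1 h, in the presence of a further agent that is not named here; a higher number here means a weaker inhibitor, a lower number a stronger inhibitor. Compound 2 `CC(C)CC1C(=O)N(C)c2cnc(Nc3ccc(S(N)(=O)=O)cc3)nc2N1C` gives 77 nM, and compound 3 `CCc1ccccc1C1C(=O)N(C)c2cnc(Nc3ccc(S(N)(=O)=O)cc3)nc2N1C` gives 51 nM. The step of a 6.2-fold lower number from compound 1 to compound 2 (0.79 log units; beyond the scatter) and the step of a 9.4-fold lower number from compound 1 to compound 3 (0.97 log units; beyond the scatter) both lie beyond the scatter, whereas the step of a 1.5-fold lower number from compound 2 to compound 3 (0.18 log units; within the scatter) does not, so compound 3 has the lowest number of the three but cannot be separated from compound 2.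

Compound 4 `COc1ccccc1C1C(=O)N(C)c2cnc(Nc3ccc(S(N)(=O)=O)cc3)nc2N1C` keeps the aromatic ring of compound 3 and changes only its substituent: methoxy in place of ethyl on an aromatic carbon. For the measured compounds named here, none of the measured steps alters a group on this ring; they all replace the whole group on the saturated ring carbon. Compounds 2 and 3 show that two quite different groups there give numbers within the scatter of each other, which gives no reason to expect a large shift from a small swap on the ring. The step of a 1.2-fold higher number from compound 3 to compound 4 (0.07 log units; within the scatter) is therefore expected to stay within the scatter, and compound 4 is estimated at 60 nM, between 25 nM and 150 nM.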

Compound 4, half-maximal inhibitory concentration: 251 nM
Beside the measured number, compound 4's estimate is 4.2-fold (0.62 log units) below it, and the stated range ends below it.
By their numbers in this assay, from the lowest: compounds 3 and 2 (each within the scatter of the next); then compounds 4 and 1 (each within the scatter of the next).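

In this assay, for the compounds shown here, the substituent on the aromatic ring matters more than the earlier compounds could show: methoxy in place of ethyl, with the same count of heavy atoms, gives a 4.9-fold higher number from compound 3 to compound 4 (0.69 log units; beyond the scatter) and so moves the number clearly. An aromatic ring on the saturated ring carbon is thus not enough to keep the number low: the 2-methoxyphenyl group gives a 3.3-fold higher number from compound 2 to compound 4 (0.51 log units; beyond the scatter) when set against isobutyl and a 1.9-fold lower number from compound 1 to compound 4 (0.28 log units; within the scatter) when set against ethyl. Nothing shown here offers an explanation for this shift.

Only ethyl and methoxy appear at this place on the aromatic ring, so a single data pair cannot show a trend. Going by these compounds, whether a chlorine, a hydroxyl or a longer chain such as propyl would give a number nearer compound 3 or compound 4 remains open.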